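A few compounds are considered here, and "the series" means these few. Any claim that something is new, unique, unknown or untested is made for them only; others in the source may bear on it.

Measured in an assay for displacement of a labelled ligand from protein deacetylase HDAC6 (Homo sapiens), read by fluorescence polarization, with a stated time of 10 min; on this read-out lower numbers stand for stronger inhibition and higher numbers for weaker inhibition:
compound 1 `O=C(O)CCc1nc2ccccc2nc1OCCOc1ccccn1` gives 110000 nM
compound 2 `Cn1c(=O)c(CCC(=O)O)nc2ccccc21` gives 70000 nM
compound 3 `Cc1cccc(OCCOc2nc3ccccc3nc2CCC(=O)O)c1` gives 180000 nM

Compound 1 stands second highest of these three numbers; compound 2 with 70000 nM lies nearest and compound 3 with 180000 nM furthest, both within the scatter. Compound 4 `Cn1ccnc1COc1nc2ccccc2nc1CCC(=O)O` differs from compound 1 by 1-methyl-1H-imidazol-2-yl in place of ((pyridin-2-yl)oxy)methyl on a saturated chain carbon bound to an oxygen on an aromatic ring. Going by the values given here, the one measured step at this place is a 1.6-fold higher number from compound 1 to compound 3 (0.21 log units; within the scatter), which exchanged the group on that oxygen without moving the number beyond the scatter. Compound 1 and compound 2 likewise sit within the scatter of one another. The step from compound 1 to compound 4 is therefore expected to stay within the scatter in this assay, with no direction favoured: a 1.1-fold lower number from compound 1 to compound 4 (0.04 log units; within the scatter). Compound 4 is estimated at 100000 nM, with a range from 40000 nM to 250000 nM.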

Compound 4, half-maximal inhibitory concentration: 140000 nM
Beside the measured number, compound 4's estimate is 1.4-fold (0.15 log units) below it; the range from low to high includes it.
By their numbers in this assay, from the lowest: compounds 2, 1, 4 and 3 (each within the scatter of the next, the first and the last beyond it).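

In this assay, the exchange of ((pyridin-2-yl)oxy)methyl for 1-methyl-1H-imidazol-2-yl gives a 1.3-fold higher number from compound 1 to compound 4 (0.10 log units; within the scatter). The earlier step exchanged only the group on the chain oxygen, whereas this one replaces the whole ((pyridin-2-yl)oxy)methyl, and the number still stays within the scatter. No evidence bears on why this position tolerates both changes. All the compounds shown carry the carboxylic acid, so it remains open whether a hydroxamic acid in its place, or an amine on the saturated chain carbon, would move the number beyond the scatter.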